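Hydroxymethyl for formyl on a drimane acid core

A few compounds are considered here, and "the series" means these few. Any claim that something is new, unique, unknown or untested is made for them only; others in the source may bear on it.

Of the compounds shown here, three have been tested in an ADME assay on C8166 cells (Homo sapiens) for cytotoxicity, read by MTT assay; on this read-out lower numbers stand for higher toxicity in this test and higher numbers for lower toxicity in this test. Compound 1, `C[C@@H]1C[C@H](O)[C@@]2(C)C(C=O)=CCC[C@@H]2[C@@]1(C)CC(=O)O`, gives 713000 nM, the highest of the three numbers, so it is the least toxic of them in this assay. Compound 2, `C=C[C@](C)(O)CC[C@@]1(C)[C@H](C)C[C@H](O[C@@H]2O[C@@H](C)[C@H](O[C@@H]3O[C@H](COC(C)=O)[C@@H](O)[C@H](O)[C@H]3O)[C@@H](O)[C@H]2O)[C@@]2(C)C(C)=CCC[C@H]12`, gives 121000 nM, and compound 3, `C=C[C@](C)(O)CC[C@@]1(C)[C@H](C)C[C@H](O[C@@H]2O[C@@H](C)[C@H](O[C@@H]3O[C@H](CO)[C@@H](OC(C)=O)[C@H](O)[C@H]3O)[C@@H](O)[C@H]2O)[C@@]2(C)C(C)=CCC[C@H]12`, gives 305000 nM; both of these numbers lie below that of compound 1 by more than the usual scatter, the gap to compound 3 being the smaller and the gap to compound 2 the larger.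

Compound 4, `C[C@@H]1C[C@H](O)[C@@]2(C)C(CO)=CCC[C@@H]2[C@@]1(C)CC(=O)O`, has not yet been measured in this assay. It differs from compound 1 in one place: hydroxymethyl in place of formyl on a double-bonded ring carbon. The shared core of compound 1 is otherwise kept.

Within the data shown here, no pair among the measured compounds differs in a single place, so no comparable step is available to guide the expectation. The author expects the step from compound 1 to compound 4 to be small, at most a modest rise in the half-maximal cytotoxic concentration, as a 1.3-fold higher number from compound 1 to compound 4 (0.10 log units; within the scatter). For compound 4 the estimate in this assay is 900000 nM, with a range from 400000 nM to 2000000 nM.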

Compound 4, half-maximal cytotoxic concentration: 709000 nM
Compound 4: the middle estimate sits 1.3-fold (0.10 log units) above what was measured; measured number inside the range.
By their numbers in this assay, from the lowest: compound 2; then compound 3; then compounds 4 and 1 (each within the scatter of the next).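

Among these compounds, this is the first step at a single place that can be read in this assay, and replacing formyl with hydroxymethyl on a double-bonded ring carbon gives a 1.0-fold lower number from compound 1 to compound 4 (0.00 log units; within the scatter), which leaves compound 1 and compound 4 within the scatter of each other. At this position of the shared core, the two groups therefore cannot be told apart in this test, even though hydroxymethyl carries a hydrogen-bond donor and formyl carries none. Nothing at hand accounts for this result, so it stands as an observation without an explanation.

The compounds shown cover only these two groups at this ring carbon, so it remains open whether an amine, a carboxylic acid or a longer chain placed there would also stay within the scatter of compound 1 in this assay. As far as these compounds go, it also remains open whether the same swap would read alike on a different core, since this single step comes from one pair of compounds in one test.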